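This account rests on a few compounds, and the source may have more. Where it says the series, first, only, none or still open, it means among the compounds named here.

Measured so far:
- compound 1, `CCOC(=O)N[C@H](C)c1nc2ccc(F)cc2s1`, 4.2 in a physicochemical assay for lipophilicity, using the shake flask method, measured as octanol-water partition, with a stated time of 15 min; a lower number here means a more polar compound, a higher number a more lipophilic compound
- compound 2, `C[C@@H](NC(=O)OCCBr)c1nc2ccc(F)cc2s1`, 3.17 in this assay

Going by the values given here, compound 2 holds the lowest of the two numbers in this assay; its nearest neighbour is compound 1, and the only step between them, a number 1.03 log units lower from compound 1 to compound 2 (beyond the scatter), lies beyond the scatter. Compound 3, `C[C@@H](NC(=O)OCC(F)(F)F)c1nc2ccc(F)cc2s1`, has not yet been measured. It differs from compound 2 in one place: trifluoromethyl in place of bromomethyl on a saturated chain carbon bound to an oxygen next to a carbonyl group. Among the compounds with values here, no measured step covers this exchange directly; the single step seen so far shows only that putting bromo on the chain of compound 1 gave a large fall to compound 2. Swapping bromomethyl for trifluoromethyl is a different change, so the expectation rests on weak ground. The estimate for compound 3 is a modest rise, a number 0.53 log units higher from compound 2 to compound 3 (beyond the scatter), staying short of compound 1. Compound 3 is therefore expected to give about 3.7 in this assay, within a range from 3.1 to 4.3.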

Compound 3, partition coefficient: 2.69
For compound 3 the middle estimate is 1.01 log units above the measured one; measured number outside the range, below it.
By their numbers in this assay, from the lowest: compound 3; then compound 2; then compound 1.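

In this assay, trifluoromethyl in place of bromomethyl on a saturated chain carbon bound to an oxygen next to a carbonyl group gives a number 0.48 log units lower from compound 2 to compound 3 (beyond the scatter) and so goes further down than the bromo compound had gone. Trifluoromethyl in place of methyl at the same place gives a number 1.51 log units lower from compound 1 to compound 3 (beyond the scatter) as the largest step among these compounds, which puts methyl, bromomethyl and trifluoromethyl in a clear order, each separated from the others by more than the scatter. Nothing measured here explains why the three groups fall in this order.

Still open, going by these compounds, is where other groups at this place would stand against these three, such as chloromethyl, hydroxymethyl, an amine or a longer chain like propyl. The compounds shown also leave open whether the same order would hold on a core other than the shared one.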